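The compounds below may be only part of what the source reports. "The series", "measured", "known", "first", "only" and "open" are said of these compounds alone.

Of the compounds shown here, three sharing a common core have been measured in a functional assay on SK-HEP1 cells (Homo sapiens) for inhibition, read by sulforhodamine B assay, with a stated time of 48 h; on this read-out higher numbers stand for weaker inhibition and lower numbers for stronger inhibition. Compound 1 `O=C(Nc1ccc2c(c1)CCN2c1ccc(C(=O)NO)cc1)Nc1ccc(Cl)c(C(F)(F)F)c1` gives 4100 nM, compound 2 `O=C(Nc1ccc(C(=O)NO)cc1)Nc1ccc(Cl)c(C(F)(F)F)c1` gives 3800 nM, and compound 3 `O=C(Nc1ccc2c(c1)CCCN2c1ccc(C(=O)NO)cc1)Nc1ccc(Cl)c(C(F)(F)F)c1` gives 3400 nM. Among these three numbers compound 2 stands second highest; its nearest companion is compound 1 and its furthest is compound 3, and both gaps lie within the scatter, so the three compounds cannot be placed in any order of inhibition on this read-out. Among the measured compounds shown here, no pair of measured compounds differs in just one place, so no measured step is available as a guide.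

Compound 4 `O=C(/C=C/c1ccc(NC(=O)Nc2ccc(Cl)c(C(F)(F)F)c2)cc1)NO` differs from compound 2 in one place: 2-(hydroxycarbamoyl)ethenyl in place of hydroxycarbamoyl on an aromatic carbon. For the measured compounds named here, no measured pair shows this change, and the three measured values give no direction for it; what remains is that compound 2 and its companions all sit in a narrow band. Compound 4 is estimated to give 1800 nM in this assay, with a range from 500 nM to 6500 nM. The step of a 2.1-fold lower number from compound 2 to compound 4 (0.32 log units; beyond the scatter) is expected to be a modest gain in inhibition, only slightly beyond the scatter, and the data here neither confirm nor contradict its direction.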

Compound 4, half-maximal inhibitory concentration: 3200 nM
Compound 4: the middle estimate sits 1.8-fold (0.25 log units) below what was measured; low and high end bracket the measured number.
By their numbers in this assay, from the lowest: compounds 4, 3, 2 and 1 (each within the scatter of the next).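

In this assay, the exchange of hydroxycarbamoyl for 2-(hydroxycarbamoyl)ethenyl on an aromatic carbon para to a large group amounts to a 1.2-fold lower number from compound 2 to compound 4 (0.07 log units; within the scatter) and is the only single-place step among the compounds shown. It shows that at this position, the longer 2-(hydroxycarbamoyl)ethenyl group, with one more double bond outside aromatic rings, leaves the number indistinguishable from that of compound 2, so this change gives no readable gain or loss in inhibition on this read-out. Nothing available here explains why the number holds steady across this change.

On these data alone, it remains open whether a group other than the hydroxycarbamoyl end, such as a carboxylic acid or an amine, would keep the number in the same band at this position, and whether a longer chain or a saturated ethyl link carrying the hydroxycarbamoyl would do the same. As far as these compounds go, it is also open whether 2-(hydroxycarbamoyl)ethenyl would give a similarly small step on the cores of compound 1 and compound 3.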